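This account rests on a few compounds, and the source may have more. Where it says the series, first, only, none or still open, it means among the compounds named here.

Measured compounds in a functional assay on A-375 cells (Homo sapiens) for antiproliferative activity, read by MTT assay, with a stated time of 48 h, in the presence of a further agent that is not named here; a lower number here means a stronger inhibitor, a higher number a weaker inhibitor: compound 1 `O=C(Nc1ccc(-n2ccc3c(NC(=O)c4ccccc4)nccc32)cc1)Nc1ccc(Cl)c(Cl)c1`, 200 nM; compound 2 `O=C(Nc1ccc(-n2ccc3c(NC(=O)c4ccccc4)nccc32)cc1)Nc1cccc(C(F)(F)F)c1`, 7000 nM.

Going by the values given here, compound 2 gives the highest number of the two, and the only measured step, a 35-fold higher number from compound 1 to compound 2 (1.54 log units; beyond the scatter), separates it from compound 1. Compound 3 `CCN1CCN(Cc2ccc(NC(=O)Nc3ccc(-n4ccc5c(NC(=O)c6ccccc6)nccc54)cc3)cc2C(F)(F)F)CC1` carries the change ((4-ethylpiperazin-1-yl)methyl in place of hydrogen on an aromatic carbon). Among the compounds with values here, no measured step touches this kind of change, since the one known step concerns the groups on the urea-bound ring itself, so the size of the step in this assay is open; a step no larger than the scatter, or a modest move to a lower number, is the expectation. For compound 3 the estimate is 3000 nM, between 700 nM and 15000 nM, which means an expected step of a 2.3-fold lower number from compound 2 to compound 3 (0.37 log units; beyond the scatter).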

Compound 3, half-maximal inhibitory concentration: 95 nM
Estimate against measurement, compound 3: 32-fold (1.50 log units) above; measured number below the stated range.
By their numbers in this assay, from the lowest: compound 3; then compound 1; then compound 2.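

In this assay, a (4-ethylpiperazin-1-yl)methyl group placed ortho to a trifluoromethyl group gives a 74-fold lower number from compound 2 to compound 3 (1.87 log units; beyond the scatter). Going by these compounds alone, the earlier step only exchanged 3,4-dichlorophenyl for 3-(trifluoromethyl)phenyl, and this is the first sign that this aromatic carbon can take a large group and reach a much lower number. Nothing measured here explains the size of this step.

As far as these compounds go, whether the piperazine ring, its ethyl group or the methyl link drives the step stays open, and a morpholine or a dimethylamino group on the same link would help separate them. From the compounds shown here alone, whether the same group acts alike on the 3,4-dichlorophenyl ring of compound 1 is also open.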